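The compounds below may be only part of what the source reports. "The series", "measured", "known", "first", "only" and "open" are said of these compounds alone.

Measured so far:
compound 1 `CC(=O)NCc1ccccc1-c1ccc(COC2CC[C@H](N3CCCCCC3)[C@H]2OC/C=C\CCC(=O)O)cc1`, 126 nM in a functional assay for antagonist activity at thromboxane A2 receptor (Rattus norvegicus); a lower number here means tighter binding, a higher number weaker binding;
compound 2 `O=C(O)CC/C=C\CO[C@H]1C(OCc2ccc(-c3ccccc3)cc2)CC[C@@H]1N1CCCCC1`, 794 nM; 63.1 nM (2 entries) in this assay.

Compound 1 stands on a single number in this assay, and a further entry for it carries no single number. Compound 2 has several entries, and their spread the several entries of compound 2 in this assay, 794 nM; 63.1 nM (2 entries) is wide, so how compound 2 stands against compound 1 cannot be settled. Compound 3 `CC(=O)NCc1ccc(-c2ccc(COC3CC[C@H](N4CCCCCC4)[C@H]3OC/C=C\CCC(=O)O)cc2)cc1` has not been measured. It differs from compound 1 in one place: 4-(acetamidomethyl)phenyl in place of 2-(acetamidomethyl)phenyl on an aromatic carbon. The same atoms are present in both, joined differently, with the group now sitting on an aromatic carbon para to a large group. Among the compounds with values here, no step between two measured compounds shows what such a move does, so the change is expected to be modest, possibly within the scatter, with no clear direction. Compound 3 is expected to give about 160 nM in this assay, within a range from 30 nM to 800 nM. This corresponds to an expected step of a 1.3-fold higher number from compound 1 to compound 3 (0.10 log units; within the scatter).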

Compound 3, dissociation constant: 20 nM
Compound 3: middle estimate off by 8.0-fold (0.90 log units), on the high side; measured number below the stated range.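

Swapping 2-(acetamidomethyl)phenyl for 4-(acetamidomethyl)phenyl keeps the same atoms and the same hydrogen-bond counts, yet it gives a 6.3-fold lower number from compound 1 to compound 3 (0.80 log units; beyond the scatter) in this assay. Within the data shown here, this is the first measured pair that differs in one place, so it is the first sign that the position of this group on its aromatic ring matters here, and not only which atoms are present. One caution applies, because entries for a single compound can lie far apart in this kind of measurement: the several entries of compound 2 in this assay, 794 nM; 63.1 nM (2 entries).

The compounds shown leave open whether this result belongs to the acetamidomethyl group itself, or whether a carboxylic acid or an amine on the same aromatic carbon would behave alike. They also leave open what a longer chain carrying the amide would do there.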